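This account rests on a few compounds, and the source may have more. Where it says the series, first, only, none or still open, it means among the compounds named here.

In a functional assay on HGC-27 cells (Homo sapiens) for cytotoxicity, read by MTT assay, with a stated time of 72 h (a higher number here means a weaker inhibitor, a lower number a stronger inhibitor), compound 1 `FC(F)(F)c1ccc(CSc2nc(N3CCCCC3)c3ccccc3n2)cc1` gives > 50000 nM, which is a limit of the assay and not a number. Compound 2 `CCOc1ccccc1Nc1nc(SCc2ccc(C(F)(F)F)cc2)nc2ccccc12` in this assay likewise gives > 50000 nM, again a limit. The step that the two limits leave unreadable from compound 1 to compound 2 therefore cannot be read, since (the limit of > 50000 nM in this assay, at which 2 of the 2 values shown sit). Compound 3 `FC(F)(F)c1ccc(CSc2nc(Nc3cccc(C(F)(F)F)c3)c3ccccc3n2)cc1` differs from compound 2 by 3-(trifluoromethyl)phenyl in place of 2-ethoxyphenyl on a nitrogen on an aromatic ring. Among the measured compounds shown here, no measured step bears on this change, and compound 2 stands only at the limit, so no step in this assay beyond the scatter is expected in either direction. Compound 3 is therefore expected near 60000 nM, between 20000 nM and 200000 nM, most likely again reported as a limit. The expected step is a step that the limit leaves unreadable from compound 2 to compound 3.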

Compound 3, half-maximal inhibitory concentration: 11700 nM
Compound 3: the middle estimate sits 5.1-fold (0.71 log units) above what was measured, outside the stated range (below it).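

In this assay, a change on this nitrogen now gives a readable difference: an at least 4.2-fold lower number from compound 2 to compound 3 (0.63 log units; beyond the scatter). Putting (3-(trifluoromethyl)phenyl)amino in place of piperidin-1-yl on the aromatic carbon gives an at least 4.2-fold lower number from compound 1 to compound 3 (0.63 log units; beyond the scatter). Both sizes remain open-ended because compound 1 and compound 2 each stand at a limit and not at a number: the limit of > 50000 nM in this assay, at which 2 of the 3 values shown sit.

The compounds shown leave open whether the trifluoromethyl group itself matters or whether a plain phenyl or a chlorophenyl on the same nitrogen would give a similar value. They also leave open how far a value of this order can be lowered on this nitrogen.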